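Shared-core series: aryl swap on the aromatic nitrogen

This account rests on a few compounds, and the source may have more. Where it says the series, first, only, none or still open, it means among the compounds named here.

Measured so far, in a functional assay on HepG2 cells (Homo sapiens) for inhibition, read by MTT assay, with a stated time of 72 h; on this read-out higher numbers stand for weaker inhibition and lower numbers for stronger inhibition:
- compound 1 `N#Cc1cccc(-n2cc(COc3cccc(NC(=O)Nc4ccc(Cl)c(C(F)(F)F)c4)c3)nn2)c1`: compound 1 gives 2760 nM
- compound 2 `CCc1ccccc1-n1cc(COc2cccc(NC(=O)Nc3ccc(Cl)c(C(F)(F)F)c3)c2)nn1`: compound 2 gives 3530 nM
- compound 3 `O=C(Nc1cccc(OCc2cn(-c3cccc(F)c3)nn2)c1)Nc1ccc(Cl)c(C(F)(F)F)c1`: compound 3 gives 2120 nM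

Compound 3 sits at the low end of the three numbers, but its separation from the others is small: a 1.3-fold lower number from compound 1 to compound 3 (0.11 log units; within the scatter) and a 1.7-fold lower number from compound 2 to compound 3 (0.22 log units; within the scatter) are both within the scatter, so the three measured compounds are not distinguished by this read-out. The aryl group on the aromatic nitrogen has so far been varied without effect beyond the scatter; a 1.3-fold higher number from compound 1 to compound 2 (0.11 log units; within the scatter) is the third such step and is likewise within the scatter.

Compound 4 `COc1ccccc1-n1cc(COc2cccc(NC(=O)Nc3ccc(Cl)c(C(F)(F)F)c3)c2)nn1` continues the same kind of change: 2-methoxyphenyl in place of 3-fluorophenyl on an aromatic nitrogen. All three measured steps bear on it, as each exchanges the aryl group on the same aromatic nitrogen, and none moved the number beyond the scatter. For the measured compounds named here, no measured pair tests a methoxy group, so the 2-methoxyphenyl is new to the set. On this basis compound 4 is expected to fall in the same band as the measured three, with no step beyond the scatter, the expected step being a 1.4-fold higher number from compound 3 to compound 4 (0.14 log units; within the scatter). The estimate for compound 4 in this assay is 2900 nM, with a range from 1400 nM to 6000 nM.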

Compound 4, half-maximal inhibitory concentration: 11300 nM
The estimate for compound 4 lay 3.9-fold (0.59 log units) below the measured number, and the stated range ends below it.
By their numbers in this assay, from the lowest: compounds 3, 1 and 2 (each within the scatter of the next); then compound 4.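

In this assay, for the compounds shown here, the aryl group on the aromatic nitrogen now proves able to move the number: 2-methoxyphenyl gives the first steps at this position beyond the scatter (a 5.3-fold higher number from compound 3 to compound 4 (0.73 log units; beyond the scatter); a 4.1-fold higher number from compound 1 to compound 4 (0.61 log units; beyond the scatter)). The closest comparison is methoxy in place of ethyl on an aromatic carbon (a 3.2-fold higher number from compound 2 to compound 4 (0.51 log units; beyond the scatter)), and since compound 2 stays within the scatter of both compound 1 and compound 3, the shift in this set goes with 2-methoxyphenyl and not with every exchange of the aryl group. No measurement on hand gives a reason for the shift.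

With a single methoxy compound, the compounds shown leave open whether the change depends on the ring oxygen-linked methyl as a whole or on its place on the aryl ring, which 2-hydroxyphenyl, 2-ethoxyphenyl and 3-methoxyphenyl analogues would help separate. They also leave open whether an amine or a carboxylic acid on the same aryl ring would shift the number in the same direction, or leave it within the band of compound 1, compound 2 and compound 3.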